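Swapping chloro for fluoro on a fused aromatic ring

The compounds below may be only part of what the source reports. "The series", "measured", "known", "first", "only" and "open" are said of these compounds alone.

Compound 1 `Cc1c(C2c3ccccc3S(=O)(=O)N2CCO)c2ccccc2n1CC(=O)O` gives 1400 nM in an assay on cells for binding affinity to prostaglandin D2 receptor 2 (Homo sapiens), read by radioligand binding; a lower number here means a stronger inhibitor, a higher number a weaker inhibitor.
Compound 2 `Cc1noc(C)c1CN1C(c2c(C)n(CC(=O)O)c3ccc(Cl)cc23)c2ccccc2S1(=O)=O` gives 8 nM in this assay.
Compound 3 `Cc1c(C2NS(=O)(=O)c3ccccc32)c2cc(Cl)ccc2n1CC(=O)O` gives 690 nM in this assay.

Compound 3 stands second highest of the three numbers: compound 1 is its nearest neighbour, with a somewhat higher number, while compound 2 lies far below it. Within the data shown here, the only single-site step among the measured compounds is an 86-fold higher number from compound 2 to compound 3 (1.94 log units; beyond the scatter), a change on the sulfonamide nitrogen, which does not touch the halogen position.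

Compound 4 `Cc1c(C2NS(=O)(=O)c3ccccc32)c2cc(F)ccc2n1CC(=O)O` differs from compound 3 by fluoro in place of chloro on an aromatic carbon. Among the measured compounds shown here, no measured pair isolates this particular exchange, so there is no step to lean on, and the reasonable expectation is a step of no more than the usual scatter in this assay, in either direction. Compound 4 is therefore estimated at 900 nM, with a range of 350 nM to 2500 nM, which corresponds to an expected step of a 1.3-fold higher number from compound 3 to compound 4 (0.12 log units; within the scatter).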

Compound 4, inhibition constant: 430 nM
The estimate for compound 4 lay 2.1-fold (0.32 log units) above the measured number; measured number inside the range.
By their numbers in this assay, from the lowest: compound 2; then compounds 4 and 3 (each within the scatter of the next); then compound 1.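

Fluoro in place of chloro on this aromatic carbon gives a 1.6-fold lower number from compound 3 to compound 4 (0.21 log units; within the scatter) in this assay, so the two halogens cannot be told apart at this position on the shared core. Among these compounds, this is the first direct look at this place, and the exchange is small beside the step on the sulfonamide nitrogen, which is an 86-fold higher number from compound 2 to compound 3 (1.94 log units; beyond the scatter). At least for compounds with a hydrogen on that nitrogen, this exchange leaves the number within the usual spread of repeat measurements, and no measurement here offers any explanation for that.

Still open, on these data alone, is whether bromo, methoxy or a nitrile on this same carbon would move the number beyond the scatter. As far as these compounds go, it is also open whether the chloro-to-fluoro exchange stays this small when (3,5-dimethyl-1,2-oxazol-4-yl)methyl sits on the sulfonamide nitrogen.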